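Cyclopropyl to Hydroxymethyl on a Trimethoxyphenyl Amide

A few compounds are considered here, and "the series" means these few. Any claim that something is new, unique, unknown or untested is made for them only; others in the source may bear on it.

Compound 1, `COc1ccc(CN(C(=O)C2CC2)c2cc(OC)c(OC)c(OC)c2)cc1O`: 59 nM
Compound 2, `COc1cc(NCc2ccc(Br)cc2)cc(OC)c1OC`: > 80000 nM

Among the measured compounds shown here, in a functional assay on MGC-803 cells (Homo sapiens) for inhibition, read by MTT assay, with a stated time of 48 h (a higher number here means a weaker inhibitor, a lower number a stronger inhibitor), compound 1 gives 59 nM, the only numerical value shown. Compound 2 returns a limit, (the limit of > 80000 nM in this assay, at which 1 of the 2 values shown sits), and not a number. Compound 3, `COc1ccc(CN(C(=O)CO)c2cc(OC)c(OC)c(OC)c2)cc1O`, is not yet measured; it differs from compound 1 by hydroxymethyl in place of cyclopropyl on a carbonyl carbon. For the measured compounds named here, no comparable step between measured compounds exists. Compound 3 is expected to be somewhat weaker, with an estimated step of a 4.2-fold higher number from compound 1 to compound 3 (0.63 log units; beyond the scatter) in this assay, beyond the scatter. Compound 3 is estimated at 250 nM, within 50 nM to 2000 nM.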

Compound 3, half-maximal inhibitory concentration: 160 nM
The estimate for compound 3 lay 1.6-fold (0.19 log units) above the measured number, and the stated range covers the measured number.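

In this assay the change gives the first step read at this carbonyl carbon: a 2.7-fold higher number from compound 1 to compound 3 (0.43 log units; beyond the scatter), modest but beyond the scatter. Compound 3 still gives a number, so the three-membered ring can leave and hydroxymethyl, with its hydrogen-bond donor and acceptor, can enter without activity being lost altogether. Nothing shown gives a reason for the size of this step. The compounds shown do not separate the effect of the ring leaving from that of hydroxymethyl entering. They also leave open how an amine, a carboxylic acid or a longer chain would read at this carbonyl carbon.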